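Swapping the aryl substituent on a shared core

The source may report more compounds than this note shows. Statements on the series, on what has been measured and on what is new or still open speak of the compounds shown alone.

Measured compounds:
Compound 1 `COc1cc(-n2cnc3ccc(-c4cccc(F)c4)cc32)cc(OC)c1OC`, in a functional assay on A549 cells (Homo sapiens) for antiproliferative activity, read by MTT assay, with a stated time of 72 h (on this read-out lower numbers stand for stronger inhibition and higher numbers for weaker inhibition), compound 1 gives 5270 nM.
Compound 2 `COc1cc(-n2cnc3ccc(-c4ccc(C(F)(F)F)cc4)cc32)cc(OC)c1OC`, compound 2 gives 3390 nM.
Compound 3 `CCOc1ccc(-c2ccc3ncn(-c4cc(OC)c(OC)c(OC)c4)c3c2)cc1`, compound 3 gives 8550 nM.

Compound 3 has the highest number of the three. Its distance to compound 1 is small, a 1.6-fold higher number from compound 1 to compound 3 (0.21 log units; within the scatter), whereas its distance to compound 2 is larger, a 2.5-fold higher number from compound 2 to compound 3 (0.40 log units; beyond the scatter). The unmeasured compound 4 `COc1cc(-n2cnc3ccc(-c4cccc(Cl)c4)cc32)cc(OC)c1OC` differs from compound 3 in one place: 3-chlorophenyl in place of 4-ethoxyphenyl on an aromatic carbon. For the measured compounds named here, the step that bears most directly on this change is the one from compound 1 to compound 3, a 1.6-fold higher number from compound 1 to compound 3 (0.21 log units; within the scatter), run backwards, since compound 1 also carries a halogen on the same ring position as compound 4. The step of a 1.6-fold lower number from compound 1 to compound 2 (0.19 log units; within the scatter) shows that moving between two halogen-bearing rings changed little. A modest move downward is therefore expected, a 1.8-fold lower number from compound 3 to compound 4 (0.25 log units; within the scatter), landing near compound 1. Compound 4 is estimated at 4800 nM, with a range from 2200 nM to 10500 nM.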

Compound 4, half-maximal inhibitory concentration: 7050 nM
Estimate against measurement, compound 4: 1.5-fold (0.17 log units) below; the range from low to high includes it.
By their numbers in this assay, from the lowest: compounds 2, 1, 4 and 3 (each within the scatter of the next, the first and the last beyond it).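

Replacing 4-ethoxyphenyl with 3-chlorophenyl on the shared core gives a result in this assay that cannot be told apart from the original (a 1.2-fold lower number from compound 3 to compound 4 (0.08 log units; within the scatter)), even though the ring substituent differs in both kind and location. Exchanging one halogen for another on the same ring, chloro in place of fluoro, also stays within the scatter (a 1.3-fold higher number from compound 1 to compound 4 (0.13 log units; within the scatter)), so this pair isolates the halogen and shows no measurable difference. Only 4-(trifluoromethyl)phenyl separates from 3-chlorophenyl, and modestly (a 2.1-fold higher number from compound 2 to compound 4 (0.32 log units; beyond the scatter)), although compound 2 remains within the scatter of compound 1, so the aryl groups do not fall into two clean groups.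

The compounds shown leave open whether an amine or a carboxylic acid on this phenyl ring would shift the number further. Nothing available explains these differences.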